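This account rests on a few compounds, and the source may have more. Where it says the series, first, only, none or still open, it means among the compounds named here.

Compound 3 `Cc1csc(NC(=O)Cn2cc(-c3ccc(F)cc3)nn2)n1` and compound 1 `Cc1csc(NC(=O)Cn2cc(-c3ccncc3)nn2)n1` share one core and differ only by pyridin-4-yl in place of 4-fluorophenyl on an aromatic carbon. In a functional assay on BMDM cells (Mus musculus, strain C57BL/6) for inhibition, with a stated time of 2 days (on this read-out lower numbers stand for stronger inhibition and higher numbers for weaker inhibition), compound 3 gives 250 nM, while compound 1 gives 100 nM, so this exchange brings a 2.5-fold lower number from compound 3 to compound 1 (0.40 log units; beyond the scatter). Compound 2 `Cc1cc(NC(=O)Cn2cc(-c3ccc(F)cc3)nn2)no1` differs from compound 3 by 5-methyl-1,2-oxazol-3-yl in place of 4-methyl-1,3-thiazol-2-yl on an amide-type nitrogen. In this assay compound 2 reaches only a limit, > 30000 nM, which is the limit of > 30000 nM in this assay, at which 1 of the 3 values shown sits. The change of core thus gave an at least 120-fold lower number from compound 2 to compound 3 (2.07 log units; beyond the scatter). Compound 4 `Cc1cc(NC(=O)Cn2cc(-c3ccncc3)nn2)no1` has not yet been tested in this assay; it differs from compound 2 by pyridin-4-yl in place of 4-fluorophenyl on an aromatic carbon, the same change that separates compound 3 from compound 1. The step expected here is a step that the limit leaves unreadable from compound 2 to compound 4, which rests on the earlier 2.5-fold lower number from compound 3 to compound 1 (0.40 log units; beyond the scatter) seen on the other core. Compound 4 is therefore estimated at 40000 nM, within a range from 12000 nM to 150000 nM, and it may well return only a limit again.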

Compound 4, half-maximal inhibitory concentration: 430 nM
For compound 4 the middle estimate is 93-fold (1.97 log units) above the measured one; measured number below the stated range.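

In this assay the exchange of 4-fluorophenyl for pyridin-4-yl did not carry over from one core to the other at the same size, with an at least 69-fold lower number from compound 2 to compound 4 (1.84 log units; beyond the scatter) standing against the earlier step: the same change on two cores in this assay, a 2.5-fold lower number (0.40 log units; beyond the scatter) from compound 3 to compound 1 and an at least 69-fold lower number (1.84 log units; beyond the scatter) from compound 2 to compound 4, at least 27-fold (1.44 log units) apart, beyond the scatter of two such steps The exchange of the group on the amide-type nitrogen also differs in size between the two pairs, with a 4.3-fold higher number from compound 1 to compound 4 (0.63 log units; beyond the scatter) among the pyridin-4-yl compounds: the same change on two cores in this assay, an at least 120-fold lower number (2.07 log units; beyond the scatter) from compound 2 to compound 3 and a 4.3-fold lower number (0.63 log units; beyond the scatter) from compound 4 to compound 1, at least 27-fold (1.44 log units) apart, beyond the scatter of two such steps Compound 2 is recorded only as a limit of the assay, > 30000 nM, so the direction of the pyridin-4-yl exchange agrees on both cores, but its exact size on the core of compound 2 stays unread.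

The compounds shown leave open whether pyridin-3-yl or a phenyl ring bearing a carboxylic acid would show the same gap between the two cores. They also leave open how an ethyl group in place of the methyl on either ring would behave.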